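This account rests on a few compounds, and the source may have more. Where it says the series, first, only, none or still open, it means among the compounds named here.

Compound 3 `CCN(CC)c1cc2[nH]c(C3CCCCC3)nc2cc1NC(=O)c1ccc(C)cc1` is one of three compounds examined in an ADME assay on Vero cells (Chlorocebus sabaeus) for cytotoxicity, read by resazurin assay, with a stated time of 3 days; on this read-out higher numbers stand for weaker inhibition and lower numbers for stronger inhibition. For compound 3 the result is only a limit, > 100 ug/mL. Compound 2 `CCCOCC(=O)Nc1cc2nc(C3CCCCC3)[nH]c2cc1N(CC)CC` likewise stops at a limit, > 100 ug/mL. For compound 1 `CCCCCC(=O)Nc1cc2nc(C3CCCCC3)[nH]c2cc1N(CC)CC` this assay reports "not determined" (no result reported). The step that the two limits leave unreadable from compound 2 to compound 3 therefore has no readable size, as both of its values sit at the limit of > 100 ug/mL in this assay, at which 2 of the 3 values shown sit. Compound 4 `CCN(CC)c1cc2[nH]c(C3CCCCC3)nc2cc1NC(=O)NCc1ccccc1` differs from compound 3 by benzylamino in place of 4-methylphenyl on a carbonyl carbon. Among the compounds with values here, no measured step shows how such a change acts here, and the single comparison available is a limit on both sides, so no shift beyond the scatter is expected. Compound 4 is accordingly estimated at 100 ug/mL, with a range from 40 ug/mL to 300 ug/mL. The step of a number no higher from compound 3 to compound 4 (the limit leaves the size open) that this estimate implies is expected to stay within the scatter.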

Compound 4, half-maximal inhibitory concentration: > 100 ug/mL
Compound 4: no number, only a limit; the forecaster's own chance of this, stated with the estimate: 75%; the middle value sits exactly at the limit.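

Compound 4 also stops at a limit, so neither its step from compound 2 nor its step from compound 3 can be read: the limit of > 100 ug/mL in this assay, at which 3 of the 4 values shown sit. The compounds shown leave open whether changing the group on the carbonyl carbon alters the result in this assay at all.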